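The source may hold more compounds than are shown below. What is called first, only, known or untested is meant among the compounds shown, and "the series" means these compounds.

Measured in a functional assay on MCF7 cells (Homo sapiens) for antiproliferative activity, read by sulforhodamine B assay, with a stated time of 48 h; a lower number here means a stronger inhibitor, a higher number a weaker inhibitor:
compound 1 `Cc1cccc(NS(=O)(=O)c2ccc(N3CCNC3=O)cc2)c1`: 190 nM
compound 2 `CCCCc1ccc(NS(=O)(=O)c2ccc(N3CCNC3=O)cc2)cc1`: 770 nM
compound 3 `CCCCOc1ccc(NS(=O)(=O)c2ccc(N3CCNC3=O)cc2)cc1`: 870 nM

Compound 1 gives the lowest number of the three; compound 2 is nearest and compound 3 furthest, both beyond the scatter. Compound 4 `COc1ccc(NS(=O)(=O)c2ccc(N3CCNC3=O)cc2)cc1` differs from compound 1 by 4-methoxyphenyl in place of 3-methylphenyl on a sulfonamide nitrogen. Within the data shown here, no measured step swaps these two groups directly. Among the measured compounds shown here, the only measured step that bears on it, oxygen inserted between ring and chain, is a 1.1-fold higher number from compound 2 to compound 3 (0.05 log units; within the scatter), so the methoxy oxygen alone is not expected to move the number. Compounds 2 and 3, carrying butyl and butoxy, both stand well above compound 1, so a weakening step is expected in this assay, of uncertain size. Compound 4 is estimated at 450 nM (range 180 nM to 1100 nM), an expected step of a 2.4-fold higher number from compound 1 to compound 4 (0.37 log units; beyond the scatter).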

Compound 4, half-maximal inhibitory concentration: > 1000 nM
Compound 4: no number, only a limit; the forecaster's own chance of this, stated with the estimate: 3%; at least 2.2-fold (0.34 log units) between middle value and limit.
By their numbers in this assay, from the lowest: compound 1; then compounds 2 and 3 (each within the scatter of the next). At a limit, above all of these: compound 4.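

In this assay, compound 4 carries only a limit: the limit of > 1000 nM in this assay, at which 1 of the 4 values shown sits. Even so, 4-methoxyphenyl in place of 3-methylphenyl on a sulfonamide nitrogen gives an at least 5.2-fold higher number from compound 1 to compound 4 (0.72 log units; beyond the scatter), a step that is at least modest, so the group on this nitrogen can shift the number beyond the scatter without a butyl or butoxy chain. The other two steps, an at least 1.1-fold higher number from compound 3 to compound 4 (0.06 log units; that floor lies within the scatter) and an at least 1.2-fold higher number from compound 2 to compound 4 (0.11 log units; that floor lies within the scatter), have floors that lie within the scatter, so they cannot be read.

Going by these compounds, it remains open whether this step follows from the methoxy group itself or from its place on the ring. On these data alone, how an amine or a carboxylic acid on that ring would read in this assay also stays open.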